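Swapping 4-hydroxyphenyl for 2-methylphenyl on the shared core

The source may report more compounds than this note shows. Statements on the series, on what has been measured and on what is new or still open speak of the compounds shown alone.

In a functional assay on A549 cells (Homo sapiens) for inhibition, read by MTT assay, with a stated time of 24 h (on this read-out higher numbers stand for weaker inhibition and lower numbers for stronger inhibition), compound 3 (`CC1(C)[C@H]2CC[C@]1(C)N(Cc1cn(-c3ccc(O)cc3)nn1)C(=O)C2`) gives 140 nM as the lowest number of the three measured compounds. Compound 1 (`CC1(C)[C@H]2CC[C@]1(C)N(Cc1cn(-c3cccc(C#N)c3)nn1)C(=O)C2`) gives 440 nM and compound 2 (`COc1ccccc1-n1cc(CN2C(=O)C[C@@H]3CC[C@@]2(C)C3(C)C)nn1`) gives 350 nM on the same read-out, and a 1.3-fold lower number from compound 1 to compound 2 (0.10 log units; within the scatter) stays within the scatter. Compound 3 stands apart from both, since a 3.1-fold lower number from compound 1 to compound 3 (0.50 log units; beyond the scatter) and a 2.5-fold lower number from compound 2 to compound 3 (0.40 log units; beyond the scatter) are modest steps beyond the scatter.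

Compound 4 (`Cc1ccccc1-n1cc(CN2C(=O)C[C@@H]3CC[C@@]2(C)C3(C)C)nn1`) has not yet been measured. It carries 2-methylphenyl in place of 4-hydroxyphenyl on an aromatic nitrogen, a change counted as 2-methylphenyl in place of 4-hydroxyphenyl on an aromatic nitrogen here. For the measured compounds named here, no measured compound carries 2-methylphenyl, so the nearest guide is compound 2 with its 2-methoxyphenyl, where a 2.5-fold lower number from compound 2 to compound 3 (0.40 log units; beyond the scatter) marks the reverse of the change in question. A modest rise in the number is therefore expected, estimated as a 2.5-fold higher number from compound 3 to compound 4 (0.40 log units; beyond the scatter) in this assay for this swap. For compound 4 the estimated value is 350 nM with an expected range of 140 nM to 850 nM on this read-out.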

Compound 4, half-maximal inhibitory concentration: 90 nM
Compound 4: middle estimate off by 3.9-fold (0.59 log units), on the high side, and the stated range ends above it.
By their numbers in this assay, from the lowest: compounds 4 and 3 (each within the scatter of the next); then compounds 2 and 1 (each within the scatter of the next).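

In this assay, 2-methylphenyl and 4-hydroxyphenyl on the aromatic nitrogen give numbers that cannot be told apart, with a 1.6-fold lower number from compound 3 to compound 4 (0.19 log units; within the scatter), so among these compounds a group with no hydrogen-bond donor or acceptor serves as well as one that has both. The change of methoxy to methyl on the aromatic carbon, the only difference between these two compounds, gives a 3.9-fold lower number from compound 2 to compound 4 (0.59 log units; beyond the scatter), which shows that this one group on the phenyl ring moves the number beyond the scatter. The 3-cyanophenyl comparison gives a 4.9-fold lower number from compound 1 to compound 4 (0.69 log units; beyond the scatter), also a modest step beyond the scatter.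

Nothing available explains why any of these steps occurs. Open too, from the compounds shown here alone, is whether ethyl or chlorine in place of the methyl would keep the number, or whether an amine or a carboxylic acid on the phenyl ring would.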